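Chloro step from compound 2 to compound 3

The source may hold more compounds than are shown below. What is called first, only, known or untested is meant among the compounds shown, and "the series" means these compounds.

In a functional assay on KB cells (Homo sapiens) for inhibition, read by MTT assay, with a stated time of 24 h, tested at 0.1 ug/mL (on this read-out higher numbers stand for more inhibition of growth at the one concentration tested and lower numbers for less inhibition of growth), compound 1 `O=C(CCCCC(S)CCS)NO` gives 7.62%, and compound 2 `O=C(CCCCC(S)CCS)Nc1ccccc1` gives 9.49%. These two numbers lie within the scatter of each other, so the pair cannot be ordered, and compound 2 stands level with compound 1 on the present data.

Within the data shown here, the only measured step shows a number 1.9 percentage points higher from compound 1 to compound 2 (within the scatter), with phenyl in place of hydroxy on an amide-type nitrogen. Among the measured compounds shown here, that step concerns a different place in the structure, and no measured step covers a substituent on the aromatic ring of compound 2.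

Compound 3 `O=C(CCCCC(S)CCS)Nc1cccc(Cl)c1` differs from compound 2 by chloro in place of hydrogen on an aromatic carbon, meta to a large group. For the measured compounds named here, the data offer no direction for this change, and the one step available stays within the scatter, so no shift beyond the scatter is expected in this assay.

The estimated outcome is a number 0.5 percentage points higher from compound 2 to compound 3 (within the scatter). For compound 3 the expected value is 10%, with an estimated range of 3% to 22%.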

Compound 3, percent growth inhibition at one concentration: "not active" (no number reported)
Compound 3: no number reported, so the estimate cannot be set against anything.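

Among these compounds, compound 3 carries only the label "not active" in this assay, with no number reported, so no step from compound 2 to compound 3 can be read. Nothing measured here bears on this result.

The compounds shown leave open whether chloro in place of hydrogen on the aromatic ring shifts growth inhibition at all.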